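Widening the saturated ring on a shared core

This account rests on a few compounds, and the source may have more. Where it says the series, first, only, none or still open, it means among the compounds named here.

Compound 1 `Cn1cc(NC(=O)c2cnc3ccc(N[C@@H]4CCCNC4)nn23)c(C(F)F)n1`: 1200 nM
Compound 2 `Cn1cc(NC(=O)c2cnc3ccc(N[C@H]4CCCNC4)nn23)c(C(F)F)n1`: 22300 nM
Compound 3 `Cn1cc(NC(=O)c2cnc3ccc(N[C@@H]4CCNC4)nn23)c(C(F)F)n1`: 8300 nM

In a functional assay on TMD8 cells (Homo sapiens) for cytotoxicity, read by CCK-8 assay, with a stated time of 72 h (on this read-out higher numbers stand for weaker inhibition and lower numbers for stronger inhibition), compound 3 gives 8300 nM, the second highest of the three numbers. It lies closer to compound 2 than to compound 1. Compound 4 `Cn1cc(NC(=O)c2cnc3ccc(N[C@@H]4CCCCNC4)nn23)c(C(F)F)n1` has not yet been measured. Its structure departs from that of compound 3 as follows: azepan-3-yl in place of pyrrolidin-3-yl on a nitrogen on an aromatic ring. In short, azepan-3-yl stands in place of pyrrolidin-3-yl on a nitrogen on an aromatic ring.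

Among the compounds with values here, no measured compound carries the seven-membered ring, so the nearest guidance comes from the change between the piperidin-3-yl and pyrrolidin-3-yl compounds. These steps are modest and run in opposite directions: a 6.9-fold higher number from compound 1 to compound 3 (0.84 log units; beyond the scatter), but a 2.7-fold lower number from compound 2 to compound 3 (0.43 log units; beyond the scatter). The large 19-fold higher number from compound 1 to compound 2 (1.27 log units; beyond the scatter) arises from the fact that compounds 1 and 2 differ only in the configuration as drawn, so ring size alone does not set the outcome.

Compound 1, with its larger ring, points towards a lower number through a 6.9-fold higher number from compound 1 to compound 3 (0.84 log units; beyond the scatter), while compound 2 goes against that trend. A modest move towards a lower number is therefore expected, with little confidence in its direction. The expected step is a 2.4-fold lower number from compound 3 to compound 4 (0.38 log units; beyond the scatter). For compound 4 the estimated value is 3500 nM, with an expected range of 900 nM to 14000 nM.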

Compound 4, half-maximal inhibitory concentration: 1200 nM
Compound 4: middle estimate off by 2.9-fold (0.46 log units), on the high side; low and high end bracket the measured number.
By their numbers in this assay, from the lowest: compounds 1 and 4 (each within the scatter of the next); then compound 3; then compound 2.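

In this assay, going from the five-membered to the seven-membered ring does not continue a steady trend with ring size, since the azepan-3-yl compound reads a 6.9-fold lower number from compound 3 to compound 4 (0.84 log units; beyond the scatter), and against the piperidin-3-yl compound of the same series the result is no change at the digits printed from compound 1 to compound 4 (within the scatter). At this nitrogen on an aromatic ring, the larger ring is therefore tolerated as well as the better of the two six-membered compounds, and the pyrrolidin-3-yl compound is the one of these three that stands apart. The other six-membered compound lies far off, with a 19-fold lower number from compound 2 to compound 4 (1.27 log units; beyond the scatter), so ring size alone does not order the series, and the one cause the data offer for the gap between the two piperidin-3-yl compounds is this: the fact that compounds 1 and 2 differ only in the configuration as drawn.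

The compounds shown leave open whether configuration counts as much on the azepan-3-yl ring as on the piperidin-3-yl ring, as only one form of the seven-membered ring appears here. They also leave open how an eight-membered azocan-3-yl ring or an open aminopropyl chain would read in the same place.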